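This account rests on a few compounds, and the source may have more. Where it says the series, first, only, none or still open, it means among the compounds named here.

In a functional assay on HEL cells (Homo sapiens) (on this read-out higher numbers stand for lower toxicity in this test and lower numbers for higher toxicity in this test), compound 3 `CCCCCc1cc2cn(COCCO)c(=O)nc2o1`, which carries a pentyl chain, gives > 200000 nM, and this value is a limit, not a number. Where compound 3 has pentyl, compound 2 `O=c1nc2occc2cn1COCCO` has hydrogen, and compound 2 gives > 200000 nM, also a limit. Compound 1 `CCCCCCCCCc1cc2cn(COCCO)c(=O)nc2o1` carries butyl in place of a hydrogen on the chain, and compound 1 gives >= 100000 nM, again a limit.

Compound 4 `CCCCCCc1cc2cn(COCCO)c(=O)nc2o1` differs from compound 3 by methyl in place of hydrogen on a saturated chain carbon, five bonds along the chain from an aromatic carbon. For the measured compounds named here, two measured steps bear on this change, a step that the two limits leave unreadable from compound 2 to compound 3 and a step that the two limits leave unreadable from compound 1 to compound 3. Neither has a readable size, so neither offers a measured size to carry over. No step beyond the scatter is expected in this assay, and a further limit is the likely report. The expected size is a number no higher from compound 3 to compound 4 (the limit leaves the size open). For compound 4 the estimated value is 200000 nM, with an expected range of 100000 nM to 400000 nM.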

Compound 4, half-maximal cytotoxic concentration: > 200000 nM
Compound 4 ended at the assay's limit (the forecaster's own chance of this, stated with the estimate: 90%); the middle value lies on the limit itself.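

In this assay, the steps joining compound 4 to compound 1, compound 2 and compound 3 cannot be read; all four values are limits. The compounds shown leave open the concentration at which any of them becomes toxic to these cells, and whether the length of the chain alters it.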